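Series notes: amine variation on the shared indole-triazole core

The compounds below may be only part of what the source reports. "The series", "measured", "known", "first", "only" and "open" are said of these compounds alone.

Measured so far:
Compound 1 `CN(Cc1cccs1)C1CCN(CCCc2c[nH]c3ccc(-n4cnnc4)cc23)CC1` — 4.3 nM
Compound 2 `OC[C@H](NC1CCN(CCCc2c[nH]c3ccc(Cn4cncn4)cc23)CC1)c1ccccc1` — 23 nM
Compound 3 `CN(Cc1ccc(S(C)(=O)=O)cc1)C1CCN(CCCc2c[nH]c3ccc(-n4cnnc4)cc23)CC1` — 18 nM

In an assay on CHO cells for displacement of a labelled ligand from 5-hydroxytryptamine receptor 1D (Homo sapiens) (a lower number here means a stronger inhibitor, a higher number a weaker inhibitor), compound 1 gives 4.3 nM, the lowest of the three numbers; compound 3 is nearest and compound 2 furthest, both beyond the scatter. Going by the values given here, the one single-point step measured so far, a 4.2-fold higher number from compound 1 to compound 3 (0.62 log units; beyond the scatter), shows that exchanging the aromatic group on the chain carbon bound to the amine nitrogen costs a modest amount.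

Compound 4 `C[C@H](NCC1CCN(CCCc2c[nH]c3ccc(-n4cnnc4)cc23)CC1)c1ccccc1` is not yet measured. It differs from compound 1 in ((1-phenylethyl)amino)methyl in place of methyl((thiophen-2-yl)methyl)amino on a saturated ring carbon. This is a larger change than the step from compound 1 to compound 3: the amine moves from a ring carbon onto a chain carbon, becomes secondary, and the aromatic group changes to phenyl with a defined stereocentre. Among the compounds with values here, no measured pair isolates this change. Compound 2 carries a secondary amine with a phenyl group on a different core and gives 23 nM, but its core differs from compound 4 as well, so it only shows that such an amine can be tolerated. Given the direction of the step from compound 1 to compound 3, a modest weakening is expected, a 3.5-fold higher number from compound 1 to compound 4 (0.54 log units; beyond the scatter). Compound 4 is therefore estimated at 15 nM, with a range from 5 nM to 45 nM.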

Compound 4, half-maximal inhibitory concentration: 4.4 nM
Beside the measured number, compound 4's estimate is 3.4-fold (0.53 log units) above it, and the stated range ends above it.
By their numbers in this assay, from the lowest: compounds 1 and 4 (each within the scatter of the next); then compounds 3 and 2 (each within the scatter of the next).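

In this assay the exchange on the saturated ring carbon gives a 1.0-fold higher number from compound 1 to compound 4 (0.01 log units; within the scatter) and so shows that this place can take ((1-phenylethyl)amino)methyl in place of methyl((thiophen-2-yl)methyl)amino with no readable loss, although the amine, the aromatic ring and the defined stereocentre all differ in the entering group. Set against a 4.2-fold higher number from compound 1 to compound 3 (0.62 log units; beyond the scatter) for the exchange of thiophen-2-yl for 4-(methylsulfonyl)phenyl, this shows that the two changes made to compound 1 do not have the same outcome here, so a large change at this place does not by itself lead to a readable loss. Nothing available bears on the reason for this result.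

The compounds shown do not separate the parts of the exchange, so the secondary amine, the phenyl group and the stereocentre cannot be judged one at a time on the shared core. Still open, on these data alone, is whether the opposite configuration at the stereocentre, or a pyridin-2-yl group in place of the phenyl, would stay within the scatter of compound 1 on this amine.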